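Sulfonyl sulfur substituent swap: compound 2 to compound 3

The source may report more compounds than this note shows. Statements on the series, on what has been measured and on what is new or still open speak of the compounds shown alone.

Measured so far in a toxicity assay on Vero cells (Chlorocebus sabaeus) for cytotoxicity, read by MTT assay (on this read-out higher numbers stand for weaker inhibition and lower numbers for stronger inhibition), as the read-out
- compound 1 `COC(=O)NC(=O)c1ccsc1NC(=O)c1ccc(S(=O)(=O)N2CCC(OC)CC2)cc1` gives 18 ug/mL
- compound 2 `COC(=O)NC(=O)c1ccsc1NC(=O)c1ccc(S(=O)(=O)N(C)C)cc1` gives 16.2 ug/mL

Among the compounds with values here, compound 2 stands level with compound 1, the only other measured compound, within the scatter. Next comes compound 3 `COC(=O)NC(=O)c1ccsc1NC(=O)c1ccc(S(=O)(=O)NC2CCC(F)(F)CC2)cc1` with the change (4,4-difluorocyclohexyl)amino in place of dimethylamino on a sulfonyl sulfur in which (4,4-difluorocyclohexyl)amino replaces dimethylamino on a sulfonyl sulfur. Within the data shown here, the one measured step bearing on this is a 1.1-fold lower number from compound 1 to compound 2 (0.05 log units; within the scatter) and it is also a swap on a sulfonyl sulfur, within the scatter. Among the measured compounds shown here, no measured compound carries the incoming group, so the range stays wide. In this assay the expected step is a 1.2-fold lower number from compound 2 to compound 3 (0.06 log units; within the scatter) and none beyond the scatter is anticipated. Compound 3 is estimated at 14 ug/mL with an expected range from 6 ug/mL to 32 ug/mL for now.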

Compound 3, half-maximal inhibitory concentration: 49 ug/mL
For compound 3 the middle estimate is 3.5-fold (0.54 log units) below the measured one; measured number outside the range, above it.
By their numbers in this assay, from the lowest: compounds 2 and 1 (each within the scatter of the next); then compound 3.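

In this assay this position on the sulfonyl sulfur can shift the number beyond the scatter: (4,4-difluorocyclohexyl)amino gives a 3.0-fold higher number from compound 2 to compound 3 (0.48 log units; beyond the scatter) and a 2.7-fold higher number from compound 1 to compound 3 (0.43 log units; beyond the scatter), while dimethylamino and 4-methoxypiperidin-1-yl stay level. Relative to dimethylamino, the swap brings in a carbon-only six-membered ring, fluorine and a hydrogen-bond donor all at once. No supporting data tie the higher number to any one of these features.

Open, as far as these compounds go, is whether plain cyclohexylamino, without fluorine, would stay with compound 3. Also open, from the compounds shown here alone, is whether 4,4-difluoropiperidin-1-yl, which keeps the ring and fluorine but lacks the donor, would stand nearer compound 1 or compound 3.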